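Swapping Cyano for Ethoxycarbonyl in a Cytotoxicity Series

This account rests on a few compounds, and the source may have more. Where it says the series, first, only, none or still open, it means among the compounds named here.

Three compounds have been measured in a functional assay on HeLa cells (Homo sapiens) for cytotoxicity, read by MTT assay, with a stated time of 3 days; a lower number here means a stronger inhibitor, a higher number a weaker inhibitor:
compound 1, `Cc1ccc2nc(C)n(-n3c(N)c(C#N)c(-c4ccccc4)c(C#N)c3=O)c(=O)c2c1`, gives 5000 nM;
compound 2, `CCOC(=O)c1c(-c2ccccc2)c(C#N)c(=O)n(-n2c(C)nc3ccc(C)cc3c2=O)c1N`, gives 21000 nM;
compound 3, `Cc1ccc2nc(C)n(NC(=O)c3sc(N)c(C#N)c3N)c(=O)c2c1`, gives 15000 nM.

Compound 4, `CCOC(=O)c1c(N)sc(C(=O)Nn2c(C)nc3ccc(C)cc3c2=O)c1N`, has not yet been measured. It differs from compound 3 by ethoxycarbonyl in place of cyano on an aromatic carbon. The same kind of change has already been made once, from compound 1 to compound 2: ethoxycarbonyl in place of cyano on an aromatic carbon, and there it gave a 4.2-fold higher number from compound 1 to compound 2 (0.62 log units; beyond the scatter). The surroundings differ, though: in the earlier pair the change sits on a six-membered aromatic ring with 1 nitrogen, ortho to a phenyl group and ortho to an amino group, whereas in compound 3 it sits on a five-membered aromatic ring with 1 sulfur, next to two ring atoms that each bear an amino group. The difference between the two cores is not broken down here.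

For compound 4 a step of about a 2.7-fold higher number from compound 3 to compound 4 (0.43 log units; beyond the scatter) is expected in this assay, because the earlier step of a 4.2-fold higher number from compound 1 to compound 2 (0.62 log units; beyond the scatter) went in that direction, with wide uncertainty since the surroundings are not the same. Compound 4 is therefore estimated at 40000 nM, between 12000 nM and 150000 nM.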

Compound 4, half-maximal inhibitory concentration: 23000 nM
Compound 4: middle estimate off by 1.7-fold (0.24 log units), on the high side, within the range that was stated.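

In this assay ethoxycarbonyl in place of cyano on the core of compound 3 gives a 1.5-fold higher number from compound 3 to compound 4 (0.19 log units; within the scatter) and so does not separate the two compounds. For the compounds shown here, with only two pairs, this does not show which feature of the cores sets the size of the step, nor how the swap would behave on any further core. It does show that the step seen on the core of compound 1 cannot simply be carried over to the core of compound 3: the same change on two cores in this assay, a 4.2-fold higher number (0.62 log units; beyond the scatter) from compound 1 to compound 2 and a 1.5-fold higher number (0.19 log units; within the scatter) from compound 3 to compound 4, 2.7-fold (0.44 log units) apart, beyond the scatter of two such steps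

Going by these compounds, whether a carboxylic acid or a primary amide in the same place on either core would behave like cyano or like ethoxycarbonyl stays open. So does the outcome with a methyl ester or a longer ester chain.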